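Branching the alkyl chain on a beta-galactosidase inhibitor

The compounds below may be only part of what the source reports. "The series", "measured", "known", "first", "only" and "open" are said of these compounds alone.

Compound 1, with structure `CCCCN[C@@H]1C=C[C@H](O)[C@H](O)[C@H]1O`, gives 50000 nM in an assay for inhibition of beta-galactosidase (Homo sapiens), read by fluorescence, with a stated time of 30 min, at pH 4.5 (a higher number here means a weaker inhibitor, a lower number a stronger inhibitor), the lower of the two numbers recorded so far; compound 2, `O[C@@H]1[C@@H](O)[C@H](NC2CCCCC2)C=C[C@@H]1O`, gives 490000 nM in this assay. Compound 3, `CC(C)CCN[C@@H]1C=C[C@H](O)[C@H](O)[C@H]1O`, has not yet been measured. It differs from compound 1 by methyl in place of hydrogen on a saturated chain carbon bound to two saturated chain carbons. Among the measured compounds shown here, no measured pair shows the same change, so its effect is unknown. Because compound 1 gives 50000 nM, compound 3 is expected to stay close, with the step from compound 1 to compound 3 estimated as a 1.4-fold lower number from compound 1 to compound 3 (0.15 log units; within the scatter), within the scatter. Compound 3 is expected to give about 35000 nM, likely between 12000 nM and 100000 nM.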

Compound 3, half-maximal inhibitory concentration: 28000 nM
Beside the measured number, compound 3's estimate is 1.3-fold (0.10 log units) above it; measured number inside the range.
By their numbers in this assay, from the lowest: compounds 3 and 1 (each within the scatter of the next); then compound 2.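

Turning butyl into isopentyl, with methyl in place of hydrogen on a saturated chain carbon bound to two saturated chain carbons, gives a 1.8-fold lower number from compound 1 to compound 3 (0.25 log units; within the scatter) in this assay. This extra methyl branch at the chain's far end therefore leaves the number unchanged within the usual scatter, so this position accepts the branch without a clear gain or loss. Nothing available explains this outcome.

Still open, on these data alone, is whether a longer chain, such as hexyl, would move the number beyond the scatter. As far as these compounds go, a phenyl or a carboxylic acid at the chain's end also remains untested here.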